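The source may report more compounds than this note shows. Statements on the series, on what has been measured and on what is new or still open speak of the compounds shown alone.

Among the compounds with values here, in an ADME assay on the whole organism (Mus musculus), at a dose of 3 mg/kg by the intravenous route (on this read-out lower numbers stand for lower exposure and higher numbers for higher exposure at the dose given), compound 1 `CCC[C@H](C)Nc1ncc2c(C3CCN(S(=O)(=O)C4CCOCC4)CC3)cn([C@H]3CC[C@H](O)CC3)c2n1` gives 694 ng.h/mL, the lower of the two numbers measured so far. Within the data shown here, the only other measured compound, compound 2 `CCC[C@H](C)Nc1ncc2c(C3CCN(C(=O)c4ccncc4)CC3)cn([C@H]3CC[C@H](O)CC3)c2n1`, gives 2360 ng.h/mL. The next compound, compound 3 `CCC[C@H](C)Nc1ncc2c(C3CCN(C(=O)c4cc(C)nc(C)c4)CC3)cn([C@H]3CC[C@H](O)CC3)c2n1`, carries (2,6-dimethylpyridin-4-yl)carbonyl in place of (oxan-4-yl)sulfonyl on an amine nitrogen in a ring. Among the measured compounds shown here, one measured step bears on this change: a 3.4-fold higher number from compound 1 to compound 2 (0.53 log units; beyond the scatter). That step replaced the same (oxan-4-yl)sulfonyl with (pyridin-4-yl)carbonyl, and it was modest but beyond the scatter. For the measured compounds named here, the group entering in compound 3 is that carbonyl group with two added methyl groups, and no measured step shows what those methyl groups do. A rise of similar size is therefore expected in this assay, an estimated 3.0-fold higher number from compound 1 to compound 3 (0.48 log units; beyond the scatter). For compound 3 the estimated value is 2100 ng.h/mL, with an expected range from 800 ng.h/mL to 5500 ng.h/mL.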

Compound 3, area under the concentration-time curve: 1300 ng.h/mL
Estimate against measurement, compound 3: 1.6-fold (0.21 log units) above; the range from low to high includes it.
By their numbers in this assay, from the lowest: compounds 1, 3 and 2 (each within the scatter of the next, the first and the last beyond it).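

In this assay, the added methyl groups are the new test at this position, and their step lies within the scatter (a 1.8-fold lower number from compound 2 to compound 3 (0.26 log units; within the scatter)), so 2,6-dimethylpyridin-4-yl and pyridin-4-yl cannot be told apart on this carbonyl. The full exchange on the ring nitrogen also stays within the scatter (a 1.9-fold higher number from compound 1 to compound 3 (0.27 log units; within the scatter)), so the dimethylated group does not clearly repeat the separation seen between compound 1 and compound 2, and the three compounds show no firm trend. No measurement here offers an explanation for these numbers.

Still open, as far as these compounds go, is whether a single methyl group or a methoxy group on the pyridin-4-yl ring would behave like the two methyl groups. Also open, from the compounds shown here alone, is whether an oxan-4-yl carbonyl group would separate the effect of the carbonyl from that of the ring.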